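Methyl for hydrogen on the ring ammonium chain of compound 1

A few compounds are considered here, and "the series" means these few. Any claim that something is new, unique, unknown or untested is made for them only; others in the source may bear on it.

Compound 1, `Cc1cc(OCCCCCCC[N+]2(C)CCCC2)cc(-n2cc(C(=O)Nc3cc(F)cc(F)c3)c(=O)c3ccc(N(C)C)nc32)c1`, was tested in an assay on LX2 cells for inhibition of COL1A1 promoter (Homo sapiens), read by a luciferase reporter, with a stated time of 24 h, tested at 20 uM; a higher number here means a stronger effect of the compound at the concentration tested, a lower number a weaker effect. In this assay compound 1 gives 4.32%, the lowest of the two numbers recorded. For the measured compounds named here, compound 3, `CC[N+]1(CCCCCCCOc2ccc(-n3cc(C(=O)Nc4cc(F)cc(F)c4)c(=O)c4ccc(N(C)C)nc43)cc2C)CCCCC1`, gives 19.7% in this assay, and the gap between compound 1 and compound 3 lies beyond the usual scatter; compound 3 differs from compound 1 in more than one place, so no single step between them is drawn. Compound 2, `CN(C)c1ccc2c(=O)c(C(=O)Nc3cc(F)cc(F)c3)cn(-c3ccc(OCCCCCCC[n+]4ccccc4)cc3Cl)c2n1`, is reported in this assay as "not active" (no number reported), with no number attached.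

Compound 4, `CC[N+]1(CCCCCCCOc2cc(C)cc(-n3cc(C(=O)Nc4cc(F)cc(F)c4)c(=O)c4ccc(N(C)C)nc43)c2)CCCC1`, differs from compound 1 in one place: methyl in place of hydrogen on a saturated chain carbon bound to an amine nitrogen in a ring. Read one bond further out, the change is methyl to ethyl on the quaternary ring nitrogen. Going by the values given here, no measured pair in this set isolates such a change, so the size of the step cannot be read from the data. Compound 3, which carries an ethyl on its ring ammonium, is the stronger of the two measured numbers, but it also differs from compound 1 elsewhere, so it cannot carry the comparison alone.

Compound 4 is therefore expected to give 9% in this assay, within a range from 0% to 24%. This corresponds to an expected step of a number 4.7 percentage points higher from compound 1 to compound 4 (within the scatter), small and within the scatter.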

Compound 4, a percentage reported as inhibition, at one concentration (the size of the read-out at that concentration, not a potency): 35.1%
Compound 4: middle estimate off by 26.1 percentage points, on the low side; the whole stated range lies below it.
By their numbers in this assay, from the lowest: compound 1; then compound 3; then compound 4.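

In this assay, for the compounds shown here, the exchange of hydrogen for methyl on a saturated chain carbon bound to an amine nitrogen in a ring gives a number 30.8 percentage points higher from compound 1 to compound 4 (beyond the scatter) and so provides the first step in this set that isolates a change in one place. It shows that this position is not indifferent to the change from methyl to ethyl: a single added carbon, with no ring, no hydrogen-bond donor or acceptor and no net charge, is enough to produce a large step in the inhibition read at the one concentration tested. The data offer no measured basis for explaining the size of this step.

A single pair cannot show whether the step continues with a propyl or butyl group in the same place, or whether a benzyl group would be tolerated there. As far as these compounds go, it also remains open whether the same exchange gives a step of similar size on a different ring ammonium or with another substituent in place of the methyl on the aryl ring of compound 1.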